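Dropping a Bromo Group from a Weak Adenosine Binder

The source may hold more compounds than are shown below. What is called first, only, known or untested is meant among the compounds shown, and "the series" means these compounds.

Of the compounds shown here, three sharing one core have been measured in an assay on CHO cells for displacement of a labelled ligand from adenosine receptor A1 (Homo sapiens), read by scintillation counting, with a stated time of 3 h; on this read-out lower numbers stand for stronger inhibition and higher numbers for weaker inhibition. Compound 1 `COc1ccc(Nc2nc3c(Cl)ncnc3s2)cc1` gives 11500 nM. Compound 2 `Clc1ncnc2sc(Nc3cccc(Br)c3)nc12` gives 12600 nM, the highest of the three numbers, although compound 1 lies within the scatter of it. Compound 3 `OC[C@@H]1CCCN1c1ncnc2sc(Nc3ccc(Cl)cc3)nc12` gives 629 nM, a far lower number, and compound 3 differs from compound 2 at the core itself, not only on the aromatic ring. Compound 4 `Clc1ncnc2sc(Nc3ccccc3)nc12` has not been measured; it differs from compound 2 by hydrogen in place of bromo on an aromatic carbon, meta to a large group. Among the measured compounds shown here, no measured pair isolates such a change. The step expected in this assay is a 1.3-fold higher number from compound 2 to compound 4 (0.10 log units; within the scatter), a small shift toward weaker binding that likely stays within the scatter. Compound 4 is estimated at 16000 nM, ranging from 5000 nM to 45000 nM.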

Compound 4, inhibition constant: > 100000 nM
Compound 4: a limit, no number; the forecaster's own chance of this, stated with the estimate: 20%; middle value at least 6.2-fold (0.79 log units) away from the limit.
By their numbers in this assay, from the lowest: compound 3; then compounds 1 and 2 (each within the scatter of the next). At a limit, above all of these: compound 4.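

In this assay compound 4 gives > 100000 nM, which is a limit of the assay and not a number: the limit of > 100000 nM in this assay, at which 1 of the 4 values shown sits. Hydrogen in place of bromo gives an at least 7.9-fold higher number from compound 2 to compound 4 (0.89 log units; beyond the scatter), and hydrogen in place of methoxy gives an at least 8.6-fold higher number from compound 1 to compound 4 (0.93 log units; beyond the scatter). The earlier compounds shown here all carried a group on this aromatic ring, so only now is it visible that the bare ring gives no measurable number, while bromo and methoxy each do. From the compounds shown here alone, it remains open whether fluoro, methyl or an amine on this ring would also bring back a measurable number.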